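Compound 2 and the Step to Compound 4 in Microsomes

The compounds below may be only part of what the source reports. "The series", "measured", "known", "first", "only" and "open" are said of these compounds alone.

Of the compounds shown here, three have been measured in an ADME assay on microsomes from liver (Rattus norvegicus) for metabolic stability, read by LC-MS, using NADPH, with a stated time of 10 min, tested at 0.1 uM; on this read-out higher numbers stand for fast clearance and lower numbers for slow clearance. Compound 1 `CC1SC(c2cccc(C(=O)NCCCCc3ccccc3)c2)N(c2ccc(C3CC3)cc2)C1=O` gives 3130 mL.min-1.g-1, compound 2 `O=C(NCCCCc1ccccc1)c1cccc(C2SCC(=O)N2c2cccc(-c3c[nH]nn3)c2)c1` gives 742 mL.min-1.g-1, and compound 3 `COc1ccc(F)cc1N1C(=O)CSC1c1cccc(C(=O)NCCCCn2cccn2)c1` gives 1470 mL.min-1.g-1. Compound 2 has the lowest number of the three; its gap to compound 3 lies within the usual scatter, while its gap to compound 1 lies beyond it. Compound 4 `O=C(NCCCCc1ccccc1)c1cccc(C2SCC(=O)N2c2ccccn2)c1` has not yet been measured. It differs from compound 2 in one place: a group of 6 heavy atoms (5 carbon, 1 nitrogen; one six-membered aromatic ring with 1 hetero atom) in place of a group of 11 heavy atoms (8 carbon, 3 nitrogen; one five-membered aromatic ring with 3 hetero atoms, one six-membered aromatic ring of carbon only), on an amide-type nitrogen in a ring. For the measured compounds named here, no step between two measured compounds shows a change of this kind, so its effect is unknown from the data. Compound 4 is expected to show a moderate rise in clearance, a 2.0-fold higher number from compound 2 to compound 4 (0.31 log units; beyond the scatter). Compound 4 is estimated at 1500 mL.min-1.g-1, with a range from 600 mL.min-1.g-1 to 3500 mL.min-1.g-1.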

Compound 4, intrinsic clearance in microsomes: 1480 mL.min-1.g-1
Compound 4: the middle estimate sits 1.0-fold (0.01 log units) above what was measured; measured number inside the range.
By their numbers in this assay, from the lowest: compounds 2, 3 and 4 (each within the scatter of the next); then compound 1.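

In this assay, for the compounds shown here, this is the first step that can be read at this position, on an amide-type nitrogen in a ring: a 2.0-fold higher number from compound 2 to compound 4 (0.30 log units; within the scatter). Putting pyridin-2-yl in place of the larger group with two aromatic rings therefore gives a difference that cannot be told apart from repeat-measurement scatter in this one pair. No measurement shown here offers an explanation for this result.

As far as these compounds go, it remains open whether a different group on this nitrogen, such as a phenyl ring carrying a carboxylic acid or an amine, would give a step beyond the scatter.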